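Aryl substituents at the five-membered ring of a nucleoside series

The compounds below may be only part of what the source reports. "The series", "measured", "known", "first", "only" and "open" are said of these compounds alone.

Measured compounds:
compound 1, `Nc1ncnn2c([C@@H]3O[C@H](CO)[C@@H](O)[C@H]3O)cc(C#Cc3ccccc3)c12`, 37700 nM
compound 2, `Nc1ncnn2c([C@@H]3O[C@H](CO)[C@@H](O)[C@H]3O)cc(-c3ccccc3)c12`, 65200 nM
compound 3, `Nc1ncnn2c([C@@H]3O[C@H](CO)[C@@H](O)[C@H]3O)cc(-c3ccc(Cl)cc3)c12`, 56700 nM

The three measured compounds share one core and differ only in the group attached to the five-membered aromatic ring. In a functional assay on CAPAN-1 cells (Homo sapiens) for antiproliferative activity, with a stated time of 72 h (a higher number here means a weaker inhibitor, a lower number a stronger inhibitor), compound 1 gives the lowest of the three numbers, but the gaps to the other two are small: a 1.7-fold higher number from compound 1 to compound 2 (0.24 log units; within the scatter) and a 1.5-fold higher number from compound 1 to compound 3 (0.18 log units; within the scatter), both within the scatter, so no ranking among the three is justified. Between the two directly attached aryl groups the change is also flat: a 1.1-fold lower number from compound 2 to compound 3 (0.06 log units; within the scatter).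

Compound 4, `Cc1ccccc1-c1cc([C@@H]2O[C@H](CO)[C@@H](O)[C@H]2O)n2ncnc(N)c12`, has not been measured in this assay. Its change from compound 1 is 2-methylphenyl in place of 2-phenylethynyl on an aromatic carbon. The two steps that bear on this are those from compound 1 to compound 2 and from compound 1 to compound 3, which likewise replace 2-phenylethynyl with a directly attached six-membered aromatic ring of carbon only; both gave only slightly higher numbers, within the scatter. Nothing in the data separates a 2-methylphenyl from the other two aryl groups. The expectation for compound 4 is therefore a number close to that of compound 1 or somewhat higher, a step of a 1.5-fold higher number from compound 1 to compound 4 (0.16 log units; within the scatter), not beyond the scatter. The estimate for compound 4 is 55000 nM, with a range from 28000 nM to 110000 nM.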

Compound 4, half-maximal inhibitory concentration: 97500 nM
Estimate against measurement, compound 4: 1.8-fold (0.25 log units) below, within the range that was stated.
By their numbers in this assay, from the lowest: compounds 1, 3, 2 and 4 (each within the scatter of the next, the first and the last beyond it).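

In this assay, among these compounds, 2-methylphenyl in place of 2-phenylethynyl on this aromatic carbon gives the first step to clear the scatter, though only modestly: a 2.6-fold higher number from compound 1 to compound 4 (0.41 log units; beyond the scatter). That step does not set compound 4 apart from the other directly attached aryl groups, since both a 1.7-fold higher number from compound 3 to compound 4 (0.24 log units; within the scatter) and a 1.5-fold higher number from compound 2 to compound 4 (0.17 log units; within the scatter) stay within the scatter, so the methyl and the change from 4-chlorophenyl have no readable effect here, and the only separation is between the two ends of the order of numbers. No supporting data bear on why the 2-phenylethynyl to 2-methylphenyl step is larger than the other two steps away from compound 1, which remain within the scatter.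

Among the compounds shown here, still open is whether the separation of compound 1 from compound 4 reflects the triple bond, the methyl or both, as the series holds no further pair that divides these two changes. Also open, on these data alone, is whether a group of another kind at this position, such as an aminomethyl, a carboxylic acid or a longer alkyl chain, would move the number in this assay well beyond the scatter in either direction.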